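The compounds below may be only part of what the source reports. "The series", "measured", "known", "first", "only" and "open" are said of these compounds alone.

For the measured compounds named here, in a functional assay on DU-145 cells (Homo sapiens) for inhibition, read by trypan blue exclusion, with a stated time of 96 h (on this read-out lower numbers stand for stronger inhibition of growth and higher numbers for weaker inhibition of growth), compound 3 (`Cc1ccc(CS/C(=C/c2c[nH]c3ccc(Cl)cc23)C(=O)c2ccc(Cl)cc2)cc1`) gives 1000 nM, the lowest of the three numbers measured so far. Compound 2 (`Cc1ccc(CS/C(=C/c2ccc(O)c(O)c2O)C(=O)c2ccc(Cl)cc2)cc1`) gives 50000 nM. Compound 4 (`Cc1ccc(CS/C(=C/c2cc([N+](=O)[O-])ccc2F)C(=O)c2ccc(Cl)cc2)cc1`) is compound 3 with one change: 2-fluoro-5-nitrophenyl in place of 5-chloro-1H-indol-3-yl on a double-bonded chain carbon bound to a double-bonded chain carbon. Going by the values given here, the only measured step at this place is a 50-fold lower number from compound 2 to compound 3 (1.70 log units; beyond the scatter), a large one, so a swap here can move the number considerably. The rest of compound 4 is not identical to that of compound 1 (`Cc1ccc(S/C(=C/c2cc([N+](=O)[O-])ccc2F)C(=O)c2ccc(Cl)cc2)cc1`), yet compound 1 carries the same 2-fluoro-5-nitrophenyl group and gives 10000 nM. That value points to a moderate loss of growth inhibition, so the expected change is a 4.0-fold higher number from compound 3 to compound 4 (0.60 log units; beyond the scatter). The estimate for compound 4 is 4000 nM, with an expected range of 800 nM to 20000 nM.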

Compound 4, concentration for 50% growth inhibition: 1000 nM
Beside the measured number, compound 4's estimate is 4.0-fold (0.60 log units) above it, and the stated range covers the measured number.
By their numbers in this assay, from the lowest: compounds 3 and 4 (each within the scatter of the next); then compound 1; then compound 2.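

Putting 2-fluoro-5-nitrophenyl in place of 5-chloro-1H-indol-3-yl gives no change at the digits printed from compound 3 to compound 4 (within the scatter) in this assay and shows that this place accepts a group with one ring and no hydrogen-bond donor. The same group in place of 2,3,4-trihydroxyphenyl gives a 50-fold lower number from compound 2 to compound 4 (1.70 log units; beyond the scatter) and repeats the large step seen with the indolyl group. On the sulfur, 4-methylbenzyl in place of 4-methylphenyl gives a 10-fold lower number from compound 1 to compound 4 (1.00 log units; beyond the scatter) and shows that this second place also moves the number.

No supporting data explain these steps. From the compounds shown here alone, whether an amine or a carboxylic acid on the double-bonded chain carbon would keep this level also remains open.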